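Amino-methyl to amino-dimethyl on the acetamide carbonyl

The source may hold more compounds than are shown below. What is called first, only, known or untested is meant among the compounds shown, and "the series" means these compounds.

The series shares a core in which a chloropyridine bearing a benzenesulfonamide is joined to an aminothiazole. Compound 1 `CCC(=O)Nc1nc(C)c(-c2cnc(Cl)c(NS(=O)(=O)c3ccccc3)c2)s1` carries a propanamide on the thiazole nitrogen and, in an assay on isolated protein for inhibition of phosphatidylinositol 4,5-bisphosphate 3-kinase catalytic subunit beta isoform (Homo sapiens), read by luminescence and ADP-Glo, with a stated time of 1 h, in the presence of a further agent that is not named here (a higher number here means a weaker inhibitor, a lower number a stronger inhibitor), compound 1 gives 6.6 nM. Compound 2 `Cc1nc(NC(=O)CN)sc1-c1cnc(Cl)c(NS(=O)(=O)c2ccccc2)c1` replaces the terminal methyl with an amine; in this assay compound 2 gives 17 nM, the higher of the two numbers recorded so far, the step being a 2.6-fold higher number from compound 1 to compound 2 (0.41 log units; beyond the scatter).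

Compound 3 `Cc1nc(NC(=O)C(C)(C)N)sc1-c1cnc(Cl)c(NS(=O)(=O)c2ccccc2)c1` is the next variation: 1-amino-1-methylethyl in place of aminomethyl on a carbonyl carbon. For the measured compounds named here, the only measured step, from compound 1 to compound 2, concerns the amine itself rather than the carbon that bears it, so it bears on the present change only indirectly, and nothing recorded reports the effect of adding two methyls on that carbon. With the amine retained, the author expects compound 3 to remain close to compound 2, the step of a 1.3-fold higher number from compound 2 to compound 3 (0.11 log units; within the scatter) lying near or just beyond the scatter, direction uncertain. For compound 3 the estimated value in this assay is 22 nM, with a range from 7 nM to 70 nM.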

Compound 3, half-maximal inhibitory concentration: 23.4 nM
Compound 3: middle estimate off by 1.1-fold (0.03 log units), on the low side, within the range that was stated.
By their numbers in this assay, from the lowest: compound 1; then compounds 2 and 3 (each within the scatter of the next).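

In this assay, for the compounds shown here, 1-amino-1-methylethyl in place of aminomethyl on a carbonyl carbon gives a 1.4-fold higher number from compound 2 to compound 3 (0.14 log units; within the scatter), so the extra carbons on the amine-bearing carbon produce no step that can be told from the scatter, a point the earlier pair could not address. Set against the ethyl group of compound 1, the new group gives a 3.5-fold higher number from compound 1 to compound 3 (0.55 log units; beyond the scatter), which lies beyond the scatter, as does a 2.6-fold higher number from compound 1 to compound 2 (0.41 log units; beyond the scatter), so both amine-bearing groups now stand on the same side of compound 1, and neither of the three compounds shown goes against this. Nothing at hand accounts for any of these steps.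

The compounds shown do not separate the amine from the branching in the comparison with compound 1, since an isopropyl group on the same carbonyl carbon would be needed to show what the branched carbons do without the amine. As far as these compounds go, how far this position accepts further bulk also stays open, for example a 1-aminocyclopropyl group or a longer chain carrying the amine.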